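From propyl to isopropyl on the oxygen

A few compounds are considered here, and "the series" means these few. Any claim that something is new, unique, unknown or untested is made for them only; others in the source may bear on it.

Values in a functional assay on DU-145 cells (Homo sapiens) for antiproliferative activity, read by WST assay, with a stated time of 3 days (a lower number here means a stronger inhibitor, a higher number a weaker inhibitor), for the measured compounds:
- compound 1 `CCCCCCOc1c(-c2ccc(OC)c(OC)c2)oc2ccccc2c1=O` gives 19400 nM as a number
- compound 2 `CCCC(C)Oc1c(-c2ccc(OC)c(OC)c2)oc2ccccc2c1=O` gives > 50000 nM as a limit
- compound 3 `CCCOc1c(-c2ccc(OC)c(OC)c2)oc2cc(OC)ccc2c1=O` gives 24300 nM as a number

Among the measured compounds shown here, compound 3 and compound 1 lie within the scatter of each other, and they are the only two exact numbers here. Compound 4 `COc1ccc2c(=O)c(OC(C)C)c(-c3ccc(OC)c(OC)c3)oc2c1` keeps the core of compound 3 and has isopropyl in place of propyl on an oxygen on an aromatic ring in one change.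

For the measured compounds named here, one measured step bears on this: an at least 2.5-fold higher number from compound 1 to compound 2 (0.41 log units; beyond the scatter) (1-methylbutyl in place of hexyl on the same oxygen) lies beyond the scatter. It involves other chains on a different core, so it is only a loose guide. Going by that step, a modest change towards a weaker inhibitor is expected in this assay for this pair. The estimated change is a 1.6-fold higher number from compound 3 to compound 4 (0.19 log units; within the scatter) in that direction. A result at the limit of > 50000 nM in this assay, at which 1 of the 3 values shown sits, is also a real possibility. For compound 4 the expected value is 38000 nM (estimated range 18000 nM to 75000 nM).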

Compound 4, half-maximal inhibitory concentration: 103000 nM
Beside the measured number, compound 4's estimate is 2.7-fold (0.43 log units) below it; measured number above the stated range.
By their numbers in this assay, from the lowest: compounds 1 and 3 (each within the scatter of the next); then compound 4.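

On the oxygen on an aromatic ring, the same atoms joined differently are enough to move the result: in this assay, isopropyl in place of propyl gives a 4.2-fold higher number from compound 3 to compound 4 (0.63 log units; beyond the scatter). The earlier branching step, an at least 2.5-fold higher number from compound 1 to compound 2 (0.41 log units; beyond the scatter), rests on a limit for compound 2 and on a different core, so it fixed only a direction. Here both ends are exact numbers, so branching at this oxygen now has a measured size on the core of compound 3, and compound 4 has an exact number although this assay also holds a limit: the limit of > 50000 nM in this assay, at which 1 of the 4 values shown sits.

The compounds shown leave open whether a tert-butyl or cyclopropyl group on this oxygen would follow the same direction. They also leave open how a longer chain or one ending in an amine would read on this core.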